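Sulfur substituent step from compound 3 to compound 4

The source may report more compounds than this note shows. Statements on the series, on what has been measured and on what is new or still open speak of the compounds shown alone.

Values measured in a functional assay on HeLa cells (Homo sapiens) for inhibition, read by CCK-8 assay, with a stated time of 72 h, tested at 2 uM (on this read-out higher numbers stand for more inhibition of growth at the one concentration tested and lower numbers for less inhibition of growth), so far
- compound 1 `Nc1ccccc1NC(=O)/C=C/c1ccc(CSc2cccc(F)c2)cc1` gives 2.25%
- compound 2 `CCc1ccc(SCc2ccc(/C=C/C(=O)Nc3ccccc3N)cc2)cc1` gives 3.96%
- compound 3 `Nc1ccccc1NC(=O)/C=C/c1ccc(CSc2ccc(C(F)(F)F)cn2)cc1` gives 6.07%

In this assay compound 3 gives 6.07% and cannot be told apart from compound 1 or compound 2 on these numbers. No order can be read among the three.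

Compound 4 `Nc1ccccc1NC(=O)/C=C/c1ccc(CSc2ccc(F)cc2)cc1` has not been measured. It carries 4-fluorophenyl in place of 5-(trifluoromethyl)pyridin-2-yl on a sulfur.

Within the data shown here, three measured steps bear on this change, since each swaps the group on that same sulfur (a number 1.7 percentage points higher from compound 1 to compound 2 (within the scatter); a number 3.8 percentage points higher from compound 1 to compound 3 (within the scatter); a number 2.1 percentage points higher from compound 2 to compound 3 (within the scatter)). All three are small. The closest match to the entering group is the 3-fluorophenyl of compound 1 at 2.25% in the same read-out. None of the three compounds shows what a larger change would look like, and a single measurement could still surprise. On this evidence, no step beyond the scatter is expected in this assay here.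

The step expected here is a number 2.1 percentage points lower from compound 3 to compound 4 (within the scatter) and it is an estimate only.

Compound 4 is expected at 4% (estimated range 0% to 12%).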

Compound 4, percent growth inhibition at one concentration: 7.09%
Estimate against measurement, compound 4: 3.1 percentage points below, and the stated range covers the measured number.
By their numbers in this assay, from the lowest: compounds 1, 2, 3 and 4 (each within the scatter of the next).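

The step of a number 1 percentage points higher from compound 3 to compound 4 (within the scatter) in this assay shows that the group on the sulfur can lose its ring nitrogen and its trifluoromethyl, going from 10 heavy atoms to 7, without a change that can be told from the scatter. The step of a number 4.8 percentage points higher from compound 1 to compound 4 (within the scatter) adds that 3-fluorophenyl and 4-fluorophenyl on this sulfur cannot be told apart, and the step of a number 3.1 percentage points higher from compound 2 to compound 4 (within the scatter) shows the same for fluoro and ethyl on the aromatic carbon of the phenyl group. All four groups on this sulfur therefore remain a single flat set in this read-out, now spanning a pyridine ring as well as phenyl rings with small and with chain substituents, and nothing available explains the numbers in terms of structure.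

Open, from the compounds shown here alone, is whether any group on this sulfur gives a step beyond the scatter at all, for example a phenyl ring bearing a carboxylic acid or an amine, a saturated cyclohexyl ring, or a longer alkyl chain in place of the aromatic ring. Also open is whether differences among these compounds would appear at other concentrations, since the flat picture rests on one tested concentration in one cell line.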